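Methoxy to Hydroxy on a Purine Series: Expected Shift

This account rests on a few compounds, and the source may have more. Where it says the series, first, only, none or still open, it means among the compounds named here.

Measured compounds:
compound 1, `COc1ccccc1-c1ccc(Nc2nc(N[C@H]3CC[C@H](N)CC3)nc3c2ncn3C2CCCC2)cc1`: 2350 nM
compound 2, `N[C@H]1CC[C@H](Nc2nc(Nc3ccc(-c4ccccc4O)cc3)c3ncn(C4CCCC4)c3n2)CC1`: 1490 nM
compound 3, `COc1ccccc1-c1ccc(Nc2nc(N[C@H]3CC[C@H](N)CC3)nc3c2ncn3C2CCCC2)cn1`: 460 nM

The three compounds were tested in an ADME assay on CCRF-CEM cells (Homo sapiens) for inhibition, read by fluorescence and resazurin assay, with a stated time of 72 h; a higher number here means a weaker inhibitor of growth, a lower number a stronger inhibitor of growth. Compound 1 and compound 2 differ in one place only, (hydrogen in place of methyl on an oxygen on an aromatic ring), and in this assay the step of a 1.6-fold lower number from compound 1 to compound 2 (0.20 log units; within the scatter). Compound 3 carries the methoxy group of compound 1 on a different core; the difference between the two cores is not broken down here, but in this assay compound 3 gives 460 nM, the lowest of the three numbers, and its gaps to compound 2 and compound 1 lie beyond the scatter.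

Compound 4, `N[C@H]1CC[C@H](Nc2nc(Nc3ccc(-c4ccccc4O)nc3)c3ncn(C4CCCC4)c3n2)CC1`, is not yet measured. It stands to compound 3 as compound 2 stands to compound 1: the change hydrogen in place of methyl on an oxygen on an aromatic ring is the same change, made at the same kind of place on a second core. Because the earlier step of a 1.6-fold lower number from compound 1 to compound 2 (0.20 log units; within the scatter) stayed within the scatter, a step of similar size is expected here, a 1.5-fold lower number from compound 3 to compound 4 (0.19 log units; within the scatter), so compound 4 is estimated at about 300 nM, with a likely range from 120 nM to 800 nM.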

Compound 4, concentration for 50% growth inhibition: 617 nM
Beside the measured number, compound 4's estimate is 2.1-fold (0.31 log units) below it; the measured number falls inside the stated range.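

In this assay, replacing methoxy with hydroxy on the core of compound 3 gives a 1.3-fold higher number from compound 3 to compound 4 (0.13 log units; within the scatter), so the step is small here, as it was on the core of compound 1. Setting the two results side by side shows no measurable difference between the cores: the same change on two cores in this assay, a 1.6-fold lower number (0.20 log units; within the scatter) from compound 1 to compound 2 and a 1.3-fold higher number (0.13 log units; within the scatter) from compound 3 to compound 4, 2.1-fold (0.33 log units) apart, within the scatter of two such steps. For these two pairs, then, the change carries from one core to the other without a detectable difference in size, but the opposite directions of the two steps mean nothing on their own, and two pairs do not make a rule for the whole series.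

The compounds shown leave open whether a different group in place of the hydroxy, such as an amine, or a longer chain on the oxygen, such as ethoxy, would shift the number beyond the scatter. They also leave open whether methoxy to hydroxy would stay this small on a third core.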